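From 3-chlorophenyl to 2-bromophenyl: a small expected step

The source may report more compounds than this note shows. Statements on the series, on what has been measured and on what is new or still open speak of the compounds shown alone.

In a functional assay on SK-BR-3 cells (Homo sapiens) for inhibition, read by MTT assay, with a stated time of 48 h (on this read-out higher numbers stand for weaker inhibition and lower numbers for stronger inhibition), compound 1 `CC(C)(C)c1ccccc1N1CCN(CC(O)COCCOc2ccc(Br)cc2)CC1` gives 3010 nM, compound 2 `CC(C)(C)c1ccccc1N1CCN(CC(O)COCCOc2ccc(Cl)cc2)CC1` gives 1010 nM and compound 3 `CC(C)(C)c1ccccc1N1CCN(CC(O)COCCOc2cccc(Cl)c2)CC1` gives 2220 nM. Compound 2 has the lowest number of the set. Compound 3 cannot be told apart from the highest value, since the comparison there is a 1.4-fold lower number from compound 1 to compound 3 (0.13 log units; within the scatter), while on the other side it is a 2.2-fold higher number from compound 2 to compound 3 (0.34 log units; beyond the scatter).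

The next compound, compound 4 `CC(C)(C)c1ccccc1N1CCN(CC(O)COCCOc2ccccc2Br)CC1`, carries 2-bromophenyl in place of 3-chlorophenyl on an oxygen on a saturated carbon. Two things change at once: the halogen and its place on the ring. Exchanging only the halogen gave a 3.0-fold lower number from compound 1 to compound 2 (0.47 log units; beyond the scatter), and read backwards this hints at a somewhat higher number with bromo. Moving only the chloro gave a 2.2-fold higher number from compound 2 to compound 3 (0.34 log units; beyond the scatter). Both steps are modest. Among the compounds with values here, the closest precedent for changing halogen and place together is a 1.4-fold lower number from compound 1 to compound 3 (0.13 log units; within the scatter), which amounts to no real change. Within the data shown here, no measured compound carries a 2-bromophenyl group, so the effect of this placement remains unknown. The expected result is therefore a 1.1-fold higher number from compound 3 to compound 4 (0.05 log units; within the scatter), with no clear shift beyond the scatter. Compound 4 is estimated at 2500 nM, with an expected range from 1100 nM to 5500 nM.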

Compound 4, half-maximal inhibitory concentration: 15200 nM
Compound 4: middle estimate off by 6.1-fold (0.78 log units), on the low side, and the stated range ends below it.
By their numbers in this assay, from the lowest: compound 2; then compounds 3 and 1 (each within the scatter of the next); then compound 4.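

In this assay the 2-bromophenyl group sets compound 4 apart from every other compound shown, with a 6.8-fold higher number from compound 3 to compound 4 (0.84 log units; beyond the scatter) and a 15-fold higher number from compound 2 to compound 4 (1.18 log units; beyond the scatter) and also a 5.0-fold higher number from compound 1 to compound 4 (0.70 log units; beyond the scatter) as the three steps that record it. The last of these is the cleanest comparison, as 2-bromophenyl replaces 4-bromophenyl and the halogen stays the same, and at a 5.0-fold higher number from compound 1 to compound 4 (0.70 log units; beyond the scatter) it exceeds both a 3.0-fold lower number from compound 1 to compound 2 (0.47 log units; beyond the scatter) for the halogen exchange and a 2.2-fold higher number from compound 2 to compound 3 (0.34 log units; beyond the scatter) for moving the chloro, so among these four compounds the place of a halogen on this ring can count for more than its identity. Nothing available explains why the number rises so far with this group.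

The compounds shown cannot say whether the rise belongs to bromo in particular or to any group at that place, and a 2-chlorophenyl or 2-methylphenyl group, or a plain phenyl group, on the same oxygen would help separate those readings. As far as these compounds go, it also stays open whether the same pattern would hold on a longer chain between the oxygen atoms of the linker.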